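The source may report more compounds than this note shows. Statements on the series, on what has been measured and on what is new or still open speak of the compounds shown alone.

In a functional assay on IMR-32 cells (Homo sapiens) for inhibition, with a stated time of 48 h, tested at 50 uM (a lower number here means less inhibition of growth, a higher number more inhibition of growth at the concentration tested), compound 1 (`C=C[C@@](C)(/C=C/c1ccc(OC(=O)CCC)cc1)CCC=C(C)C`) gives 54%. It stands level with compound 2 (`C=C[C@@](C)(/C=C/c1ccc(OC(=O)CCCCCCCCCCCCCCC)cc1)CCC=C(C)C`), which gives 54%. The open question concerns compound 3 (`C=C[C@@](C)(/C=C/c1ccc(OC)cc1)CCC=C(C)C`), which has not yet been measured. The change lies on an oxygen on an aromatic ring: methyl in place of propylcarbonyl on an oxygen on an aromatic ring. Methyl thus takes the place of propylcarbonyl, and the same difference, cut one bond further out, reads (propylcarbonyl)oxy to methoxy.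

Among the compounds with values here, only one measured step bears on this, and only indirectly. The step of no change at the digits printed from compound 1 to compound 2 (within the scatter) alters the saturated chain but retains the carbonyl, whereas the carbonyl leaves in compound 3. Within the data shown here, no measured compound shows what removing it does, so the evidence gives no direction for this change. Among the measured compounds shown here, with only that flat step as a guide, no shift beyond the scatter is expected, although the uncertainty is wide. The expected change is a number 4 percentage points lower from compound 1 to compound 3 (within the scatter). Compound 3 is estimated at 50%, with an expected range from 30% to 70%.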

Compound 3, percent growth inhibition at one concentration: 30%
Beside the measured number, compound 3's estimate is 20 percentage points above it; the measured number falls inside the stated range.
By their numbers in this assay, from the lowest: compound 3; then compounds 1 and 2 (each within the scatter of the next).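

In this assay, within the data shown here, what sits on an oxygen on an aromatic ring matters in a way the earlier compounds did not reveal: with methyl in place of propylcarbonyl, the result is a number 24 percentage points lower from compound 1 to compound 3 (beyond the scatter). The earlier step, no change at the digits printed from compound 1 to compound 2 (within the scatter), changed only the saturated chain and retained the carbonyl, so the step to compound 3, which removes the carbonyl, is the only one shown that moves growth inhibition beyond the scatter. The data offer no measurement that explains this fall.

The step from compound 1 to compound 3 replaces a group of 5 heavy atoms, including a hydrogen-bond acceptor, with a single carbon, so it does not show whether the loss of the carbonyl or the loss of the chain carbons accounts for the difference. Open too, as far as these compounds go, is how this assay would read with a butyl group on that oxygen, which keeps a chain without the carbonyl, with an acetyl group, which keeps the carbonyl on a shorter chain, or with a free hydroxyl in place of the ester.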